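This account rests on a few compounds, and the source may have more. Where it says the series, first, only, none or still open, it means among the compounds named here.

Measured in a functional assay on A549 cells (Homo sapiens) for inhibition, read by CCK-8 assay, with a stated time of 72 h, tested at 10 uM; a higher number here means a stronger effect of the compound at the concentration tested, a lower number a weaker effect:
compound 1, `CN(C)C(=O)c1cc2cnc(Nc3ccc(S(=O)(=O)NCCCCN=C=S)cc3)nc2n1C1CCCC1`, gives 101%
compound 2, `CN(C)C(=O)c1cc2cnc(Nc3ccc(S(=O)(=O)NCCCCCCN=C=S)cc3)nc2n1C1CCCC1`, gives 101%
compound 3, `CN(C)C(=O)c1cc2cnc(Nc3ccc(C(=O)NCCCN=C=S)cc3)nc2n1C1CCCC1`, gives 103%

Compound 1 stands level with compound 2 at the digits shown, and these two together are the lowest of the three numbers; the gap to compound 3 is a number 2 percentage points higher from compound 1 to compound 3 (within the scatter), so all three sit inside the scatter of one another and none can be called stronger or weaker.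

Compound 4, `CN(C)C(=O)c1cc2cnc(Nc3ccc(C(=O)NCCCCN=C=S)cc3)nc2n1C1CCCC1`, is compound 1 with a change on the aromatic ring: a group of 10 heavy atoms (6 carbon, 2 nitrogen, 1 oxygen, 1 sulfur; no ring) in place of a group of 11 heavy atoms (5 carbon, 2 nitrogen, 2 oxygen, 2 sulfur; no ring), on an aromatic carbon. For the measured compounds named here, two measured steps bear on this. The step to compound 3 replaces the sulfonamide-bearing group of compound 1 with the amide-bearing group and gives a number 2 percentage points higher from compound 1 to compound 3 (within the scatter). The step to compound 2 lengthens the chain on the sulfonamide side and gives no change at the digits printed from compound 1 to compound 2 (within the scatter). Neither an exchange of the sulfonamide for the amide nor a change of chain length has moved the read-out beyond the scatter, so no step beyond the scatter is expected in this assay for compound 4 either.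

The estimate for compound 4 in this assay is therefore 102%, within 94% to 108%, which is expected to amount to a number 1 percentage points higher from compound 1 to compound 4 (within the scatter).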

Compound 4, a percentage reported as inhibition, at one concentration (the size of the read-out at that concentration, not a potency): 102%
For compound 4 middle estimate and measured number coincide at the digits printed; low and high end bracket the measured number.
By their numbers in this assay, from the lowest: compounds 1, 2, 4 and 3 (each within the scatter of the next).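

Compound 4 isolates the exchange of the sulfonamide for the amide, with the chain length held, and in this assay this gives a number 1 percentage points higher from compound 1 to compound 4 (within the scatter); the earlier step to compound 3 had altered the linking group and the chain together, so it could not show this exchange alone. For the compounds shown here, the second new step, a number 1 percentage points lower from compound 3 to compound 4 (within the scatter), adds the amide-side counterpart to the chain extension earlier seen only on the sulfonamide side, so neither the linking group nor the chain length separates these compounds at this concentration. Nothing available accounts for this lack of separation.

All of the compounds shown carry the isothiocyanate at the end of the chain, so it remains open whether the read-out would hold with an amine or a carboxylic acid there instead. From the compounds shown here alone, this read-out gives the size of the effect at one concentration only, so it also remains open whether compounds 1, 2, 3 and 4 would show a stronger or weaker effect than one another at any other concentration, and whether a longer chain on the amide side would stay within the scatter.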